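The source may hold more compounds than are shown below. What is called first, only, known or untested is meant among the compounds shown, and "the series" means these compounds.

Working notes on the series. Compound 1 `CCOC(=O)c1sc(-c2cccc(NC(=O)c3ccccc3F)c2)nc1Nc1ccc(N2CCN(C)CC2)cc1` and compound 2 `CN1CCN(c2ccc(Nc3nc(-c4cccc(NC(=O)c5ccccc5)c4)sc3C(N)=O)cc2)CC1` share a core that differs in the group on the thiophene-type sulfur-bearing ring and in the benzamide. In a functional assay on Raji cells (Homo sapiens) for antiproliferative activity, read by CCK-8 assay, with a stated time of 72 h (on this read-out lower numbers stand for stronger inhibition and higher numbers for weaker inhibition), compound 1 gives 9270 nM and compound 2 gives 6360 nM; the two numbers sit close to each other and neither is singled out as stronger on that basis. Compound 3 `CN1CCN(c2ccc(Nc3nc(-c4cccc(NC(=O)c5cccc(F)c5)c4)sc3C(N)=O)cc2)CC1` carries the primary amide of compound 2 together with a 3-fluorophenyl on the benzamide carbonyl carbon; in this assay compound 3 is recorded as "not determined" (no result reported), so it stands without a value of its own. Among the measured compounds shown here, compound 4 `CN1CCN(c2ccc(Nc3nc(-c4cccc(NC(=O)c5ccccc5F)c4)sc3C(N)=O)cc2)CC1` is the one compound not yet measured. It differs from compound 3 by 2-fluorophenyl in place of 3-fluorophenyl on a carbonyl carbon. For the measured compounds named here, no step with two measured ends covers this change, so its size cannot be read from the series; the expectation is that in this assay compound 4 lands near compounds 1 and 2, with no movement beyond the scatter to be predicted in either direction. Compound 4 is therefore estimated in this assay at 7000 nM, with a range from 3000 nM to 16000 nM, because compound 1 gives 9270 nM and compound 2 gives 6360 nM.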

Compound 4, half-maximal inhibitory concentration: 3270 nM
For compound 4 the middle estimate is 2.1-fold (0.33 log units) above the measured one; the range from low to high includes it.
By their numbers in this assay, from the lowest: compounds 4, 2 and 1 (each within the scatter of the next, the first and the last beyond it).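

In this assay the series now holds its first reading of a fluoro group on the benzamide with the primary amide kept in place: fluoro in place of hydrogen on an aromatic carbon gives a 1.9-fold lower number from compound 2 to compound 4 (0.29 log units; within the scatter) and so does not separate the 2-fluorophenyl compound from the unsubstituted phenyl compound. Among the compounds shown here, with 2-fluorophenyl held fixed, amino in place of ethoxy on a carbonyl carbon gives a 2.8-fold lower number from compound 1 to compound 4 (0.45 log units; beyond the scatter) and is the only single change that exceeds the scatter, so the primary amide and the ethyl ester can be told apart here, though only modestly. No measurement bearing on either change is available, and neither step can be assigned a cause.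

The change from 3-fluorophenyl to 2-fluorophenyl cannot be read, as compound 3 has no number in this assay, so the two fluoro placements remain uncompared. Also open, as far as these compounds go, is how a chloro or methoxy group in place of the fluoro group, or a carboxylic acid or N-methyl amide in place of the primary amide, would read in this assay.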